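A few compounds are considered here, and "the series" means these few. Any claim that something is new, unique, unknown or untested is made for them only; others in the source may bear on it.

Series notes. Compound 1 `O=c1cc(CSC(=S)N2CCCC2)oc2ccccc12` carries no chloro on the shared core; in a functional assay on SW480 cells (Homo sapiens) for antiproliferative activity, read by MTT assay, with a stated time of 72 h (a higher number here means a weaker inhibitor, a lower number a stronger inhibitor), compound 1 gives 23400 nM. Compound 3 `O=c1c(Cl)c(CSC(=S)N2CCCC2)oc2ccccc12` adds chloro, and in this assay compound 3 gives 1400 nM. The step of a 17-fold higher number from compound 3 to compound 1 (1.22 log units; beyond the scatter) is hydrogen in place of chloro on an aromatic carbon. Compound 2 `CC(C)N(C(=S)SCc1cc(=O)c2ccc(Cl)cc2o1)C(C)C` bears a different amine part and chloro on the other ring; in this assay compound 2 is recorded only as a limit, > 25000 nM, which is the limit of > 25000 nM in this assay, at which 1 of the 3 values shown sits. How the cores of compound 2 and compound 3 differ is not broken down here.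

Compound 4 `CC(C)N(C(=S)SCc1cc(=O)c2ccccc2o1)C(C)C` is not yet measured. Relative to compound 2 it shows (hydrogen in place of chloro on an aromatic carbon). This is the same kind of change as from compound 3 to compound 1, not the same: there the chloro sat on a six-membered aromatic ring with 1 oxygen, ortho to a group of 1 heavy atom, ortho to a group of 9 heavy atoms and two atoms from the ring oxygen, whereas here it sits on a six-membered aromatic ring of carbon only. Because the measured step of a 17-fold higher number from compound 3 to compound 1 (1.22 log units; beyond the scatter) raised the number, the expected step is a step that the limit leaves unreadable from compound 2 to compound 4, carrying the number further past the limit. Compound 4 is expected at 45000 nM, within a range from 20000 nM to 120000 nM.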

Compound 4, half-maximal inhibitory concentration: > 40000 nM
Compound 4 gave a limit, no number; the forecaster's own chance of this, stated with the estimate: 80%; the middle value lies beyond the limit too.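

In this assay compound 2 and compound 4 are both recorded only as limits, so the step between them, hydrogen in place of chloro on an aromatic carbon, cannot be read. On these data alone, this result neither repeats nor contradicts the step of a 17-fold higher number from compound 3 to compound 1 (1.22 log units; beyond the scatter) seen with the chloro on a six-membered aromatic ring with 1 oxygen, and whether that change carries over to a six-membered aromatic ring of carbon only remains untested. Within the data shown here, the one step with a readable floor, an at least 1.7-fold higher number from compound 1 to compound 4 (0.23 log units; that floor lies within the scatter), is a different change, diisopropylamino in place of pyrrolidin-1-yl on a thiocarbonyl carbon, and it says nothing about chloro.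

The compounds shown give no pair in which chloro on the ring of carbon only can be read against hydrogen with a measured number on both sides, for instance with pyrrolidin-1-yl on the thiocarbonyl carbon. They also leave open how another amine there, such as morpholin-4-yl or piperidin-1-yl, would behave with the chloro of compound 3 in place.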